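This account rests on a few compounds, and the source may have more. Where it says the series, first, only, none or still open, it means among the compounds named here.

Measured so far in an ADME assay on WI-38 cells (Homo sapiens) for cytotoxicity, read by sulforhodamine B assay, with a stated time of 24 h; on this read-out lower numbers stand for stronger inhibition and higher numbers for weaker inhibition:
compound 1, `N#CCC(=O)N/N=C1\C(=O)Nc2ccc(S(=O)(=O)N3CCOCC3)cc21`, gives 302000 nM;
compound 2, `O=C1Nc2ccc(S(=O)(=O)N3CCOCC3)cc2/C1=N/c1cccc(C(F)(F)F)c1`, gives 226000 nM;
compound 3, `Cc1ccc(/N=C2\C(=O)Nc3ccc(S(=O)(=O)N4CCOCC4)cc32)cc1`, gives 309000 nM.

Compound 3 carries the highest of the three numbers, but its nearest neighbour is compound 1, with a 1.0-fold higher number from compound 1 to compound 3 (0.01 log units; within the scatter), and its furthest is compound 2, with a 1.4-fold higher number from compound 2 to compound 3 (0.14 log units; within the scatter), so all three compounds sit within the scatter of one another. Compound 4, `O=C1Nc2ccc(S(=O)(=O)N3CCOCC3)cc2/C1=N/Nc1ccccc1`, is the next compound in this assay. The change from compound 3 is anilino in place of 4-methylphenyl on a double-bonded nitrogen.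

Going by the values given here, no measured step swaps one group on the double-bonded nitrogen for another group that is itself attached through a nitrogen, so no step bears on the change directly. The closest are the steps that vary the same position: a 1.3-fold lower number from compound 1 to compound 2 (0.13 log units; within the scatter), a 1.0-fold higher number from compound 1 to compound 3 (0.01 log units; within the scatter) and a 1.4-fold higher number from compound 2 to compound 3 (0.14 log units; within the scatter). Each of them stayed within the scatter, even when the group changed from ((cyanomethyl)carbonyl)amino to an aryl ring, so the expectation for compound 4 is a step of no size beyond the scatter, with no direction preferred, a 1.1-fold lower number from compound 3 to compound 4 (0.03 log units; within the scatter). Compound 4 is therefore estimated at 290000 nM, within a range from 150000 nM to 550000 nM.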

Compound 4, half-maximal inhibitory concentration: 262000 nM
Compound 4: the middle estimate sits 1.1-fold (0.04 log units) above what was measured; the measured number falls inside the stated range.
By their numbers in this assay, from the lowest: compounds 2, 4, 1 and 3 (each within the scatter of the next).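

In this assay, going by these compounds alone, anilino is the first group on this double-bonded nitrogen that pairs an aromatic ring with a hydrogen-bond donor, and it leaves the number within the scatter of both aryl groups: the exchange for 4-methylphenyl gives (a 1.2-fold lower number from compound 3 to compound 4 (0.07 log units; within the scatter)), and the exchange for 3-(trifluoromethyl)phenyl gives (a 1.2-fold higher number from compound 2 to compound 4 (0.06 log units; within the scatter)). The set also now holds a change made one atom further out, on the amine nitrogen, where phenyl in place of (cyanomethyl)carbonyl gives (a 1.2-fold lower number from compound 1 to compound 4 (0.06 log units; within the scatter)), again within the scatter. Across the four compounds, then, neither an aryl group placed directly on the double-bonded nitrogen nor one carried on an amine nitrogen separates from the others, and nothing measured here offers an explanation for these small steps.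

The compounds shown leave open whether an amine, a carboxylic acid or a longer chain on the double-bonded nitrogen would produce a step beyond the scatter. They also leave open how much of this flat picture depends on the shared core, which is the same in all four compounds.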